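Chloro to hydroxy at the limit of the assay

The source may report more compounds than this note shows. Statements on the series, on what has been measured and on what is new or still open speak of the compounds shown alone.

In an ADME assay on HEK293 cells (Homo sapiens) for cytotoxicity, read by luminescence, with a stated time of 72 h (a lower number here means that less compound is needed, a higher number that more compound is needed for the effect), compound 3 `CCOC(=O)c1c(-c2cccc(Cl)c2)[nH]c2cc(OC)ccc2c1=O` gives > 22000 nM as a limit and not a number. Compound 1 `CCOC(=O)c1c(-c2cccc(OCc3ccccc3)c2)[nH]c2cc(OC)ccc2c1=O` gives > 22000 nM as a limit too. Compound 2 `CCOC(=O)c1c(-c2cccc(OC(F)(F)F)c2)[nH]c2cc(OC)ccc2c1=O` gives > 22000 nM as a limit as well. The measurements so far show the limit of > 22000 nM in this assay, at which 3 of the 3 values shown sit, and no actual number. Compared with compound 3, compound 4 `CCOC(=O)c1c(-c2cccc(O)c2)[nH]c2cc(OC)ccc2c1=O` shows hydroxy in place of chloro on an aromatic carbon with hydroxy in place of chloro on an aromatic carbon. Two measured changes bear on this spot: a step that the two limits leave unreadable from compound 1 to compound 3 and a step that the two limits leave unreadable from compound 2 to compound 3 and neither offers a size to carry over. No step beyond the scatter is therefore expected in this assay in either direction. The expected outcome is a step that the limit leaves unreadable from compound 3 to compound 4 in this comparison. For compound 4 the estimate is 30000 nM with an expected range from 10000 nM to 60000 nM and another limit is the likeliest reading.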

Compound 4, half-maximal effective concentration: > 22000 nM
Compound 4 ended at the assay's limit (the forecaster's own chance of this, stated with the estimate: 85%); the middle value lies beyond the limit too.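

Compound 4 stops at a limit, as do compound 1, compound 2 and compound 3, so no step between any of them can be read: the limit of > 22000 nM in this assay, at which 4 of the 4 values shown sit.

The compounds shown leave open what actual concentration any of them needs for the effect, and whether hydroxy, chloro, trifluoromethoxy and benzyloxy differ at all.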